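Hydroxymethyl Added to the Piperidine Amide of Compound 2

The source may report more compounds than this note shows. Statements on the series, on what has been measured and on what is new or still open speak of the compounds shown alone.

Compound 1 `Nc1ncnc2c1nc(Sc1cc3c(cc1Br)CCC3)n2CCC1CCN(C=O)CC1` and compound 2 `Nc1ncnc2c1nc(Sc1cc3c(cc1Br)OCCO3)n2CCC1CCN(C=O)CC1` share the same core and differ in the ring fused to the aryl group. In a functional assay on NCI/ADR-RES cells (Homo sapiens) for inhibition, read by luminescence, with a stated time of 72 h (a lower number here means a stronger inhibitor, a higher number a weaker inhibitor), compound 1 gives 230 nM, while compound 2 gives 2100 nM, the higher of the two numbers and a gap beyond the usual scatter. Compound 3 `Nc1ncnc2c1nc(Sc1cc3c(cc1Br)OCCO3)n2CCC1CCN(C(=O)CO)CC1` has not been measured; it keeps the frame of compound 2 and differs from it by hydroxymethyl in place of hydrogen on a carbonyl carbon. Within the data shown here, no measured pair shows this change, so its effect cannot be read from the data. The step of a 1.1-fold lower number from compound 2 to compound 3 (0.02 log units; within the scatter) is expected to be small, within the scatter, with no clear direction. Compound 3 is estimated at 2000 nM, with a range from 700 nM to 6000 nM.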

Compound 3, half-maximal inhibitory concentration: 10000 nM
Estimate against measurement, compound 3: 5.0-fold (0.70 log units) below; the measured number lies above the stated range.
By their numbers in this assay, from the lowest: compound 1; then compound 2; then compound 3.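

In this assay, the carbonyl carbon of the piperidine amide proves not to be indifferent to substitution: hydroxymethyl in place of hydrogen brings a 4.8-fold higher number from compound 2 to compound 3 (0.68 log units; beyond the scatter), a modest step toward a weaker inhibitor. This is the only single-place change shown, so it is the only direct reading of this position. No measurement given here offers an explanation for the step. Still open, from the compounds shown here alone, is whether an amine, a carboxylic acid or a longer chain at this carbonyl carbon would give a similar step, and whether hydroxymethyl would do the same on the frame of compound 1.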